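A few compounds are considered here, and "the series" means these few. Any claim that something is new, unique, unknown or untested is made for them only; others in the source may bear on it.

Of the compounds shown here, two have numbers so far. In an ADME assay on MRC5 cells (Homo sapiens) for cytotoxicity, read by fluorescence and resazurin assay, with a stated time of 3 days (a lower number here means that less compound is needed, a higher number that more compound is needed for the effect), compound 1 (`COc1ccc(Cn2cc(C3(O)C=CC(=O)C=C3)nn2)cc1`) gives 450 nM and compound 2 (`CCOC(=O)Nc1ccc(S(=O)(=O)n2c(C3(O)C=CC(=O)C=C3)cc3ccccc32)cc1`) gives 86 nM as the lower of the two, a gap beyond the usual scatter. Compound 3 (`CS(=O)(=O)c1ccc(S(=O)(=O)n2c(C3(O)C=CC(=O)C=C3)cc3ccccc32)cc1`) is still unmeasured and has methylsulfonyl in place of the (ethoxycarbonyl)amino of compound 2 on an aromatic carbon, para to a large group (methylsulfonyl in place of (ethoxycarbonyl)amino on an aromatic carbon). The rest of the structure stays the same. Among the compounds with values here, no measured pair shows this kind of exchange, so the expectation has only compound 2 at 86 nM as its anchor. In this assay the expected change is a 1.2-fold higher number from compound 2 to compound 3 (0.07 log units; within the scatter) and no shift beyond the scatter is anticipated in either direction. The estimated value for compound 3 is 100 nM (estimated range 35 nM to 300 nM for this measurement).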

Compound 3, half-maximal effective concentration: 39 nM
The estimate for compound 3 lay 2.6-fold (0.41 log units) above the measured number; the measured number falls inside the stated range.
By their numbers in this assay, from the lowest: compound 3; then compound 2; then compound 1.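

In this assay, the group on the aromatic carbon para to a large group affects the number: methylsulfonyl in place of (ethoxycarbonyl)amino gives a 2.2-fold lower number from compound 2 to compound 3 (0.34 log units; beyond the scatter), a modest step but the first measured at this position. The exchange replaces a group with 1 hydrogen-bond donor and 2 hydrogen-bond acceptors by one with 0 donors and 2 acceptors, and also goes from 6 heavy atoms to 4, but a single pair cannot separate these differences. Nothing measured on these compounds bears on why the number moved.

From the compounds shown here alone, it remains open whether a simple amine, which keeps a donor on a much smaller group, would fall with compound 2 or compound 3. A carboxylic acid at the same carbon would test whether the step extends to a group of another kind.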